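Chloro for Isopropyl: What Compound 4 Might Show

This account rests on a few compounds, and the source may have more. Where it says the series, first, only, none or still open, it means among the compounds named here.

Compound 1 `CC(C)c1ccc(-c2nc(SCc3cn(CC(=O)NC(=O)Nc4ccccn4)nn3)nc(Nc3ccccc3F)c2C#N)cc1` gives 8380 nM in a functional assay on B16-F10 cells (Mus musculus) for inhibition, read by MTT assay, with a stated time of 72 h; a higher number here means a weaker inhibitor, a lower number a stronger inhibitor.
Compound 2 `Cc1ccc(Nc2nc(SCc3cn(CC(=O)NC(=O)Nc4ccccn4)nn3)nc(-c3ccc(C(C)C)cc3)c2C#N)cc1` gives 3060 nM in this assay.
Compound 3 `Cc1cccc(Nc2nc(SCc3cn(CC(=O)NC(=O)Nc4ccccn4)nn3)nc(-c3ccc(C(C)C)cc3)c2C#N)c1` gives 1650 nM in this assay.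

Among these three numbers compound 2 stands second highest, nearer to compound 3 than to compound 1. Every measured step changes the aryl on a nitrogen on an aromatic ring: a 2.7-fold lower number from compound 1 to compound 2 (0.44 log units; beyond the scatter), a 5.1-fold lower number from compound 1 to compound 3 (0.71 log units; beyond the scatter) and a 1.9-fold lower number from compound 2 to compound 3 (0.27 log units; within the scatter). Compound 4 `Cc1ccc(Nc2nc(SCc3cn(CC(=O)NC(=O)Nc4ccccn4)nn3)nc(-c3ccc(Cl)cc3)c2C#N)cc1` departs from compound 2 at a different place: chloro in place of isopropyl on an aromatic carbon. Among the compounds with values here, no measured step touches this position, so none bears directly on it. The expected step is therefore small, a 1.3-fold higher number from compound 2 to compound 4 (0.12 log units; within the scatter), without a clear direction. Compound 4 is estimated at 4000 nM, within a range from 1500 nM to 11000 nM.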

Compound 4, half-maximal inhibitory concentration: 1320 nM
Compound 4: middle estimate off by 3.0-fold (0.48 log units), on the high side, and the stated range ends above it.
By their numbers in this assay, from the lowest: compounds 4, 3 and 2 (each within the scatter of the next, the first and the last beyond it); then compound 1.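

In this assay this position proves responsive: 4-chlorophenyl in place of 4-isopropylphenyl gives a 2.3-fold lower number from compound 2 to compound 4 (0.37 log units; beyond the scatter), the first measured change away from the aryl on the nitrogen. Isopropyl is therefore not needed at this position for the inhibition seen with compound 2, and chloro serves at least as well in this one pair. No measurement shown here explains the direction of this step.

Going by these compounds, whether the same change holds with 3-methylphenyl or 2-fluorophenyl on the nitrogen remains open, as does how a methoxy group or an amine would read at this position.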